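The compounds below may be only part of what the source reports. "The series", "measured", "known", "first", "only" and "open" are said of these compounds alone.

Compound 1 `CCn1c(-c2cnc(C)nc2)nc2c(N[C@H]3CCN(C(=O)C4CCC4)C3)ncnc21` stands highest of the three compounds measured in an ADME assay on the whole organism (Rattus norvegicus, strain Wistar Han) for pharmacokinetics; a lower number here means slower removal, a higher number faster removal of the compound: compound 1 gives 13 mL/min/kg. Compound 2 `CCn1c(-c2ccc(C(F)(F)F)nc2)nc2c(O[C@H]3CCN(C(=O)c4cocn4)C3)ncnc21` gives 1.3 mL/min/kg, and compound 3 `CCn1c(-c2ccc(C(F)(F)F)nc2)nc2c(O[C@H]3CCN(C(=O)C4CCOC4)C3)ncnc21` gives 1.2 mL/min/kg. Those two differ only in the group on the carbonyl carbon, and that exchange gave a 1.1-fold lower number from compound 2 to compound 3 (0.03 log units; within the scatter). Compound 4 `CCn1c(-c2cnc(C)nc2)nc2c(N[C@H]3CCN(C(=O)C4CC4)C3)ncnc21` differs from compound 1 at the same kind of place: cyclopropyl in place of cyclobutyl on a carbonyl carbon. Among the compounds with values here, the one measured step of this kind stayed within the scatter, so no step beyond the scatter is expected here either. For compound 4 the estimated value is 13 mL/min/kg, with a range from 7 mL/min/kg to 25 mL/min/kg. That estimate means an expected step of no change at the digits printed from compound 1 to compound 4 (within the scatter), within the scatter.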

Compound 4, clearance: 8.1 mL/min/kg
The estimate for compound 4 lay 1.6-fold (0.21 log units) above the measured number; low and high end bracket the measured number.
By their numbers in this assay, from the lowest: compounds 3 and 2 (each within the scatter of the next); then compounds 4 and 1 (each within the scatter of the next).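

In this assay, exchanging cyclobutyl for cyclopropyl on the carbonyl carbon gave a 1.6-fold lower number from compound 1 to compound 4 (0.21 log units; within the scatter) on the core of compound 1. This adds a second exchange at this kind of place that stays within the scatter, now between two rings of carbon only and on a different core from compound 2 and compound 3. No measurement here offers a reason for this result. Still open, on these data alone, is whether an open chain such as isopropyl, or a ring carrying an amine, on this carbonyl carbon would move the number beyond the scatter.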